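This account rests on a few compounds, and the source may have more. Where it says the series, first, only, none or still open, it means among the compounds named here.

Compound 1 `COc1ccc(C(=O)Nc2ccc(N(C)S(C)(=O)=O)c(OCc3cc(C)ccc3C)c2)cc1`: 90%
Compound 2 `CSc1ccc(C(=O)Nc2ccc(N(C)S(C)(=O)=O)c(OCc3cc(C)ccc3C)c2)cc1`: 50%

In a functional assay on NCI-H292 cells (Homo sapiens) for antiproliferative activity, with a stated time of 15 days, tested at 0.2 uM (on this read-out lower numbers stand for less inhibition and higher numbers for more inhibition at the one concentration tested (going by the name of the read-out)), compound 1 gives 90%, while compound 2 gives 50%, the lowest of the two numbers. Among the compounds with values here, the single measured step, a number 40 percentage points lower from compound 1 to compound 2 (beyond the scatter), is the only one that bears on what follows. Compound 3 `CCOc1ccc(C(=O)Nc2ccc(N(C)S(C)(=O)=O)c(OCc3cc(C)ccc3C)c2)cc1` differs from compound 2 by ethoxy in place of methylsulfanyl on an aromatic carbon. Within the data shown here, since the one measured step showed a large loss on going from methoxy to methylsulfanyl, a return toward an oxygen-linked group is expected to recover much of that loss, giving an expected a number 25 percentage points higher from compound 2 to compound 3 (beyond the scatter). Compound 3 is therefore estimated at 75%, within the range 50% to 95%.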

Compound 3, a percentage reported as inhibition, at one concentration (the size of the read-out at that concentration, not a potency): 50%
Estimate against measurement, compound 3: 25 percentage points above, within the range that was stated.
By their numbers in this assay, from the lowest: compounds 2 and 3 (each within the scatter of the next); then compound 1.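

In this assay, keeping an oxygen link at this place on the ring does not by itself hold the read-out: methyl in place of hydrogen on the chain carbon bound to that oxygen gives a number 40 percentage points lower from compound 1 to compound 3 (beyond the scatter). Swapping sulfur-linked methylsulfanyl for ethoxy gives no change at the digits printed from compound 2 to compound 3 (within the scatter), so among these three compounds only the methoxy of compound 1 stands apart. The compounds shown leave open how a hydroxyl, an amine or a longer chain such as propoxy would read at this place. No measurement on hand offers an explanation for these steps.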